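The source may report more compounds than this note shows. Statements on the series, on what has been measured and on what is new or still open speak of the compounds shown alone.

Compound 1, `COC(=O)c1ccccc1S(=O)(=O)N1CCCC(Cn2ccnc2)C1`, gives 53 nM.
Compound 2, `Cc1cc(S(=O)(=O)N2CCCC(Cn3ccnc3)C2)ccc1F`, gives 24 nM.
Compound 3, `O=[N+]([O-])c1cccc(Cl)c1Oc1cccc(S(=O)(=O)N2CCCC(Cn3ccnc3)C2)c1`, gives 9 nM.

All three were tested in an assay on isolated protein for inhibition of Aromatase (Homo sapiens), read by fluorescence; on this read-out lower numbers stand for stronger inhibition and higher numbers for weaker inhibition. Among these three numbers, compound 2 holds the second highest. Compound 1 lies nearest to it, with a higher number that is beyond the scatter, while compound 3 lies furthest, with a lower number that is also beyond the scatter.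

Compound 4, `O=S(=O)(c1ccc(F)c(Cl)c1)N1CCCC(Cn2ccnc2)C1`, has not yet been measured. It differs from compound 2 in one place: chloro in place of methyl on an aromatic carbon. Among the compounds with values here, no pair of measured compounds shows a step of this kind, so there is nothing to lean on beyond the size of the change itself, which is small. The expected step from compound 2 to compound 4 in this assay is therefore a 1.2-fold lower number from compound 2 to compound 4 (0.08 log units; within the scatter), which is none beyond the scatter. Compound 4 is thus expected to give about 20 nM in this assay, with a range from 8 nM to 60 nM.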

Compound 4, half-maximal inhibitory concentration: 14 nM
Compound 4: the middle estimate sits 1.4-fold (0.15 log units) above what was measured; low and high end bracket the measured number.
By their numbers in this assay, from the lowest: compounds 3, 4 and 2 (each within the scatter of the next, the first and the last beyond it); then compound 1.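

In this assay the swap of methyl for chloro on this aromatic carbon, ortho to a fluoro group, gives a 1.7-fold lower number from compound 2 to compound 4 (0.23 log units; within the scatter) and so does not separate the two groups. At this position, one carbon can give way to one chlorine without a change that stands out from repeat-measurement noise. Nothing measured here speaks to why the two groups read alike.

As far as these compounds go, whether an amine, a methoxy group or a nitrile at this position would shift the number beyond the scatter remains open. So does whether this swap reads the same at other positions on the ring.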